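The source may report more compounds than this note shows. Statements on the series, on what has been measured and on what is new or still open speak of the compounds shown alone.

Working notes on the series. Among the measured compounds shown here, compound 1 `O=S(=O)(Nc1ncccn1)c1ccc(Nc2nncc3ccccc23)cc1` and compound 2 `O=C1CS/C(=N/Nc2nncc3ccccc23)N1` are the two measured members; both carry the same hydrazine-linked core, differing in what hangs on it. In a functional assay on SK-OV-3 cells (Homo sapiens) for antiproliferative activity, read by sulforhodamine B assay, with a stated time of 72 h (on this read-out higher numbers stand for weaker inhibition and lower numbers for stronger inhibition), compound 1 gives 0.8 nM, and in the same assay compound 2 gives 0.8 nM. Compound 1 is level with compound 2 at the digits shown; the two values are within the scatter of each other, so no order between them is claimed.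

Compound 3 `Cc1cc(NS(=O)(=O)c2ccc(Nc3nncc4ccccc34)cc2)no1` is not yet measured. It differs from compound 1 in one place: 5-methyl-1,2-oxazol-3-yl in place of pyrimidin-2-yl on a sulfonamide nitrogen. For the measured compounds named here, no measured pair shows this change, so the expected step rests on the structural change alone. The change is expected to leave the number close to where compound 1 stands, with no step beyond the scatter, wording the expected step as a 1.5-fold higher number from compound 1 to compound 3 (0.18 log units; within the scatter). Compound 3 is estimated to give 1.2 nM, between 0.3 nM and 5 nM.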

Compound 3, half-maximal inhibitory concentration: 6.7 nM
Compound 3: the middle estimate sits 5.6-fold (0.75 log units) below what was measured, and the stated range ends below it.
By their numbers in this assay, from the lowest: compounds 1 and 2 (each within the scatter of the next); then compound 3.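

The sulfonamide nitrogen of compound 1 is a position where the choice of ring registers: in this assay, 5-methyl-1,2-oxazol-3-yl in place of pyrimidin-2-yl gives an 8.4-fold higher number from compound 1 to compound 3 (0.92 log units; beyond the scatter). The two groups have the same counts of heavy atoms, hydrogen-bond donors and hydrogen-bond acceptors, so these counts alone do not fix the number at this position. They differ in ring size and ring atoms, and the series offers no measurement bearing on what lies behind the step.

The compounds shown leave open whether the step follows the five-membered ring, its oxygen or its methyl, which a comparison with unsubstituted 1,2-oxazol-3-yl or 4-methylpyrimidin-2-yl would begin to separate. Also open, going by these compounds, is how a simple phenyl or an acetyl group on the same sulfonamide nitrogen would read.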